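Substituent changes on the amide aryl ring

The source may report more compounds than this note shows. Statements on the series, on what has been measured and on what is new or still open speak of the compounds shown alone.

Compound 1 `COc1ccc2c(=O)c(/C=C/C(=O)Nc3cccc(C)c3)coc2c1` in a functional assay on Huh-7 cells (Homo sapiens) for inhibition, read by MTT assay, with a stated time of 48 h; a lower number here means a stronger inhibitor, a higher number a weaker inhibitor: 15500 nM
Compound 2 `COc1ccc2c(=O)c(/C=C/C(=O)Nc3ccccc3)coc2c1` in this assay: 9050 nM

Compound 2 holds the lowest of the two numbers in this assay; its nearest neighbour is compound 1, and the step of a 1.7-fold lower number from compound 1 to compound 2 (0.23 log units; within the scatter) is within the scatter, so the two cannot be ranked. Among the measured compounds shown here, that step, hydrogen in place of methyl on an aromatic carbon, is the only measured step, and it shows that a single small change on the amide aryl ring did not move the number beyond the scatter.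

Compound 3 `COc1ccc2c(=O)c(/C=C/C(=O)Nc3ccccc3Cl)coc2c1` is not yet measured. It differs from compound 2 by chloro in place of hydrogen on an aromatic carbon. For the measured compounds named here, no measured step puts a chloro group on this ring, and no step concerns a group ortho to a large group, so the step from compound 1 to compound 2 bears on it only loosely, as a precedent for a small change on the same ring. On that basis the step of a 1.0-fold lower number from compound 2 to compound 3 (0.00 log units; within the scatter) is expected to stay within the scatter. Compound 3 is therefore estimated at 9000 nM in this assay, with a range from 3500 nM to 23000 nM.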

Compound 3, half-maximal inhibitory concentration: 58400 nM
The estimate for compound 3 lay 6.5-fold (0.81 log units) below the measured number; measured number above the stated range.
By their numbers in this assay, from the lowest: compounds 2 and 1 (each within the scatter of the next); then compound 3.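

Chloro in place of hydrogen, ortho to a large group on the amide aryl ring, gives the first change in this assay that clears the scatter: the step of a 6.5-fold higher number from compound 2 to compound 3 (0.81 log units; beyond the scatter) contrasts with the unresolved change between the two earlier compounds. Exchanging 3-methylphenyl for 2-chlorophenyl also clears it, and the step of a 3.8-fold higher number from compound 1 to compound 3 (0.58 log units; beyond the scatter) sets compound 3 apart from both earlier compounds, so this ring does not tolerate every small change alike, and a single added heavy atom at this place is enough to raise the number. Nothing at hand accounts for the rise.

The three compounds do not separate the chloro group itself from its place on the ring, since the only other substituted ring, in compound 1, carries a methyl group and at another place. From the compounds shown here alone, whether a fluoro, methoxy or amine group ortho to a large group would raise the number in the same way stays open, as does whether chloro at other places on the ring would.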